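The source may hold more compounds than are shown below. What is called first, only, known or untested is meant among the compounds shown, and "the series" means these compounds.

Measured compounds in a functional assay on J774 cells (Mus musculus) for cytotoxicity, read by resazurin assay, with a stated time of 72 h; a lower number here means a stronger inhibitor, a higher number a weaker inhibitor:

compound 1, `O=S(=O)(Nc1cccc(CO)c1)c1ccc(-c2ccccc2)cc1`: 2200 nM
compound 2, `O=S(=O)(Nc1cc(CO)cc(CO)c1)c1ccc(-c2ccc(Cl)cc2Cl)cc1`: 2500 nM
compound 3, `O=C(Nc1cccc(CO)c1)c1ccc(-c2ccccc2)cc1`: > 15000 nM, which is a limit of the assay and not a number

Of the two compounds with a number, compound 1 has the lower one, and compound 2 sits so close to it that the two cannot be told apart within the usual scatter of this kind of measurement. Going by the values given here, compound 3 gives only a limit; this is the one value that rests at the limit of > 15000 nM in this assay, at which 1 of the 3 values shown sits.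

Compound 4, `CN(C)c1ccc(-c2ccc(S(=O)(=O)Nc3cccc(CO)c3)cc2)cc1`, has not yet been measured. It differs from compound 1 in a single place: dimethylamino in place of hydrogen on an aromatic carbon, para to a large group. Among the compounds with values here, nothing among the measured compounds shows what such an addition does in this assay, so the expectation for it can only be cautious. Within the data shown here, a step no larger than the scatter is expected, in either direction, since the one change between measured compounds that kept the sulfonamide, from compound 1 to compound 2, moved the number little. Compound 4 is therefore estimated at 2000 nM, with a range from 700 nM to 6000 nM, which means an expected step of a 1.1-fold lower number from compound 1 to compound 4 (0.04 log units; within the scatter).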

Compound 4, half-maximal inhibitory concentration: > 5000 nM
Compound 4 ended at the assay's limit; the forecaster's own chance of this, stated with the estimate: 10%; middle value at least 2.5-fold (0.39 log units) from the limit.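

Putting dimethylamino in place of hydrogen on an aromatic carbon, para to a large group, gives an at least 2.2-fold higher number from compound 1 to compound 4 (0.35 log units; beyond the scatter) in this assay. Going by these compounds alone, the earlier compounds offered no pair differing in one place, so this is the first direct reading of a change at this position: going from phenyl to 4-(dimethylamino)phenyl makes the compound a weaker inhibitor in this assay, by more than the scatter, and does not leave the number where it was. The value of compound 4 is a limit of the assay and not a number, so the step has a lower bound but no known full size: the limit of > 5000 nM in this assay, at which 1 of the 4 values shown sits.

The compounds shown leave open whether a methoxy group, a primary amine or a carboxylic acid at this same place would move the number in the same direction as dimethylamino. They also leave open whether dimethylamino would have a similar effect on the core of compound 2, which carries two chlorine atoms and a second hydroxymethyl group.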